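The source may report more compounds than this note shows. Statements on the series, on what has been measured and on what is new or still open speak of the compounds shown alone.

Of the compounds shown here, two of a shared core have been tested in a functional assay on MCF7 cells (Homo sapiens) for antiproliferative activity, read by MTT assay, with a stated time of 72 h; a higher number here means a weaker inhibitor, a lower number a stronger inhibitor. Compound 1, `CC1=CC[C@H]2[C@H](CC[C@]2(C)O)C(C)(C)[C@@H]1CC[C@H]1[C@]2(C)CC[C@H](OC(=O)c3ccccc3)C(C)(C)O[C@H]2CC[C@@]1(C)O`, gives 21000 nM, the lower of the two numbers recorded. Compound 2, `CC1=CC[C@H]2[C@H](CC[C@]2(C)O)C(C)(C)[C@@H]1CC[C@H]1[C@]2(C)CC/C(=N/O)C(C)(C)O[C@H]2CC[C@@]1(C)O`, gives 46800 nM in this assay, a gap beyond the usual scatter. Compound 3, `CC1=CC[C@H]2[C@H](CC[C@]2(C)O)C(C)(C)[C@@H]1CC[C@H]1[C@]2(C)CC[C@H](OC(=O)c3ccc(C(F)(F)F)cc3F)C(C)(C)O[C@H]2CC[C@@]1(C)O`, has not yet been measured; it differs from compound 1 by 2-fluoro-4-(trifluoromethyl)phenyl in place of phenyl on a carbonyl carbon. Among the compounds with values here, no measured pair isolates this change, so the step from compound 1 to compound 3 is expected to be small, as a 1.3-fold lower number from compound 1 to compound 3 (0.12 log units; within the scatter), and could fall either way. For compound 3 the expected result in this assay is 16000 nM, within a range of 5000 nM to 45000 nM.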

Compound 3, half-maximal inhibitory concentration: > 50000 nM
Compound 3 ended at the assay's limit (the forecaster's own chance of this, stated with the estimate: 10%); middle value at least 3.1-fold (0.49 log units) away from the limit.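

In this assay compound 3 gives > 50000 nM, which is a limit of the assay and not a number. Placing 2-fluoro-4-(trifluoromethyl)phenyl in place of phenyl on a carbonyl carbon gives an at least 2.3-fold higher number from compound 1 to compound 3 (0.37 log units; beyond the scatter), so the first sign appears that this position does not tolerate every substituted ring equally. The full size of the loss cannot be read: the limit of > 50000 nM in this assay, at which 1 of the 3 values shown sits.

As far as these compounds go, the fluorine and the trifluoromethyl group enter together, so their separate shares stay unknown. Also open, from the compounds shown here alone, is whether a ring carrying only one of them, or an amine on the phenyl ring, would hold the activity of compound 1.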